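The source may hold more compounds than are shown below. What is called first, only, known or untested is meant among the compounds shown, and "the series" means these compounds.

In a functional assay on MCF7 cells (Homo sapiens) for inhibition, read by CCK-8 assay, with a stated time of 48 h (on this read-out higher numbers stand for weaker inhibition of growth and lower numbers for stronger inhibition of growth), three compounds with a shared core have been measured. Compound 1 `CN1CCN(c2ccc(Nc3ncc(Cl)c(Nc4ccccc4)n3)nc2)CC1` gives 51800 nM, compound 2 `Cc1ccc(CNc2nc(Nc3ccc(N4CCN(C)CC4)cn3)ncc2Cl)cc1` gives 38100 nM, and compound 3 `Cc1ccc(Nc2nc(Nc3ccc(N4CCN(C)CC4)cn3)ncc2Cl)cc1` gives 11400 nM. Compound 3 has the lowest of the three numbers, and so the strongest inhibition of growth so far. Compound 4 `CC(C)c1ccc(Nc2nc(Nc3ccc(N4CCN(C)CC4)cn3)ncc2Cl)cc1` has not yet been measured. It differs from compound 3 by isopropyl in place of methyl on an aromatic carbon, para to a large group: isopropyl in place of methyl on an aromatic carbon.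

The closest guide is the change of hydrogen to methyl on an aromatic carbon, which gave a 4.5-fold lower number from compound 1 to compound 3 (0.66 log units; beyond the scatter). Two other steps concern a different change, 4-methylbenzyl against an aromatic ring on the nitrogen: a 3.3-fold lower number from compound 2 to compound 3 (0.52 log units; beyond the scatter) is modest, while a 1.4-fold lower number from compound 1 to compound 2 (0.13 log units; within the scatter) stays within the scatter. Among the measured compounds shown here, no measured compound carries anything larger than methyl in this place, so the guide is thin. A small move in the same direction seems likely, and the expected step is a 1.6-fold lower number from compound 3 to compound 4 (0.21 log units; within the scatter). Compound 4 is estimated at 7000 nM, with an expected range of 2500 nM to 20000 nM.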

Compound 4, concentration for 50% growth inhibition: 1880 nM
Beside the measured number, compound 4's estimate is 3.7-fold (0.57 log units) above it; measured number outside the range, below it.
By their numbers in this assay, from the lowest: compound 4; then compound 3; then compounds 2 and 1 (each within the scatter of the next).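

In this assay, the position on the aromatic ring, para to a large group, does not stop at methyl: isopropyl in place of methyl gives a 6.1-fold lower number from compound 3 to compound 4 (0.78 log units; beyond the scatter), so the gain in growth inhibition seen with methyl continues with a larger alkyl group. Measured from the unsubstituted phenyl, isopropyl gives a 28-fold lower number from compound 1 to compound 4 (1.44 log units; beyond the scatter), and 4-isopropylphenyl in place of 4-methylbenzyl gives a 20-fold lower number from compound 2 to compound 4 (1.31 log units; beyond the scatter), so hydrogen, methyl and isopropyl in compounds 1, 3 and 4 form a falling series with no exception among these three. Nothing available here explains why the larger group gives the lower number.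

Going by these compounds, whether the numbers keep falling with a still larger group, such as tert-butyl or cyclohexyl, remains open. Also open, on these data alone, is how a group containing oxygen or nitrogen, such as methoxy, an amine or a carboxylic acid, would behave at this position.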